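Ester series on the shared core: compound 3 to compound 4

The source may report more compounds than this note shows. Statements on the series, on what has been measured and on what is new or still open speak of the compounds shown alone.

compound 1 `O=C(NCc1ccccc1)c1cn(-c2ccccc2)nc1-c1cccnc1`: "nd(insoluble)" (no result reported)
compound 2 `COc1ccc(OC(=O)c2cn(-c3ccccc3)nc2-c2cccnc2)cc1`: > 100000 nM
compound 3 `CC(C)c1cccc(OC(=O)c2cn(-c3ccccc3)nc2-c2cccnc2)c1`: 11600 nM

Among the compounds with values here, in a functional assay on Raji cells (Homo sapiens) for cytotoxicity, read by MTT assay, with a stated time of 48 h (a lower number here means a stronger inhibitor, a higher number a weaker inhibitor), compound 3 gives 11600 nM, the only plain number in the set. For compound 2 the entry is a limit of the assay, > 100000 nM. Compound 1 returned no result, "nd(insoluble)" (no result reported). Within the data shown here, the single measured step, an at least 8.6-fold lower number from compound 2 to compound 3 (0.93 log units; beyond the scatter), sits on the oxygen next to the carbonyl group, and the limit of > 100000 nM in this assay, at which 1 of the 3 values shown sits, is all that bears on its size. Compound 4 `CC(C)(C)c1ccc(OC(=O)c2cn(-c3ccccc3)nc2-c2cccnc2)cc1` differs from compound 3 by 4-(tert-butyl)phenyl in place of 3-isopropylphenyl on an oxygen next to a carbonyl group. The prior step was large but ran between groups unlike these two, so for compound 4 a change in this assay near the scatter is expected, a 1.3-fold higher number from compound 3 to compound 4 (0.11 log units; within the scatter). For compound 4 the estimate is 15000 nM, between 4000 nM and 60000 nM.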

Compound 4, half-maximal inhibitory concentration: 42300 nM
Compound 4: middle estimate off by 2.8-fold (0.45 log units), on the low side, and the stated range covers the measured number.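

On an oxygen next to a carbonyl group, two carbon-only groups are not interchangeable: 4-(tert-butyl)phenyl in place of 3-isopropylphenyl gives a 3.6-fold higher number from compound 3 to compound 4 (0.56 log units; beyond the scatter) in this assay. With tert-butyl in place of methoxy on an aromatic carbon, the series shows an at least 2.3-fold lower number from compound 2 to compound 4 (0.37 log units; beyond the scatter). That second step is bounded on one side only: the limit of > 100000 nM in this assay, at which 1 of the 4 values shown sits.

The step from compound 3 to compound 4 changes both the alkyl group and its place on the ring, and the compounds shown do not separate the two. Going by these compounds, whether a ring carrying an amine or a carboxylic acid would fit this order remains open.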